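A Larger Aryl Group in Place of Isopropyl

The source may hold more compounds than are shown below. What is called first, only, known or untested is meant among the compounds shown, and "the series" means these compounds.

Three compounds have been measured in a functional assay on SK-OV-3 cells (Homo sapiens) for antiproliferative activity, read by MTT assay, with a stated time of 72 h; on this read-out lower numbers stand for stronger inhibition and higher numbers for weaker inhibition:
compound 1 `COc1ccc(NC(=O)CCc2cccc3c2B(O)OC3)cc1` gives 900 nM
compound 2 `CC(C)c1cccc(NC(=O)CCc2cccc3c2B(O)OC3)c1` gives 510 nM
compound 3 `COc1ccccc1NC(=O)CCc1cccc2c1B(O)OC2` gives 200 nM

Among these numbers compound 2 stands second highest. Compound 1 lies nearest to it, a little higher but within the usual scatter, while compound 3 lies furthest, lower and beyond the scatter.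

Compound 4 `CC(=O)c1cccc(-c2cccc(NC(=O)CCc3cccc4c3B(O)OC4)c2)c1` has not yet been measured in this assay. It differs from compound 2 at a single point: 3-acetylphenyl in place of isopropyl on an aromatic carbon. Within the data shown here, no two measured compounds differ in only one place, so there is no measured step of this kind to lean on. Nothing among the three measured compounds shows how so large an addition at this position plays out, so the step from compound 2 to compound 4 is expected to be a 1.3-fold lower number from compound 2 to compound 4 (0.11 log units; within the scatter), not beyond the scatter. Compound 4 is therefore estimated at 400 nM, within a range from 120 nM to 1400 nM.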

Compound 4, half-maximal inhibitory concentration: 68 nM
The estimate for compound 4 lay 5.9-fold (0.77 log units) above the measured number; measured number below the stated range.
By their numbers in this assay, from the lowest: compound 4; then compound 3; then compounds 2 and 1 (each within the scatter of the next).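

In this assay, 3-acetylphenyl in place of isopropyl brings a 7.5-fold lower number from compound 2 to compound 4 (0.88 log units; beyond the scatter) and so shows that this aromatic carbon tolerates a much larger group, one that carries a second aromatic ring, and that inhibition grows stronger with it. This is the first measured single change among these compounds. Nothing measured here explains the gain.

From the compounds shown here alone, whether it comes from the added ring itself or from the acetyl group on that ring stays open. An unsubstituted phenyl at this place would separate the two, and an amine or a carboxylic acid on the ring in place of acetyl would test how much that group matters.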